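Swapping an aromatic ring for methyl on a purine amide

The compounds below may be only part of what the source reports. "The series", "measured", "known", "first", "only" and "open" are said of these compounds alone.

Measured so far:
Compound 1, `Nc1ccccc1NC(=O)c1ccc(Cn2cnc3c(Nc4ccc(-c5ccccn5)cc4)nc(Cl)nc32)cc1`: 30.8%
Compound 2, `CC(C)n1cnc2c(Nc3ccccc3)nc(NCOCc3ccc(C(=O)Nc4ccccc4N)cc3)nc21`: 34.3%

Of the compounds shown here, two have been tested in a functional assay on NCI-H460 cells (Homo sapiens) for antiproliferative activity, read by CCK-8 assay, with a stated time of 72 h, tested at 8 uM; on this read-out higher numbers stand for a stronger effect at the one concentration tested and lower numbers for a weaker effect. In this assay compound 1 gives 30.8%, and compound 2 gives 34.3%. These two numbers lie within the usual scatter of each other, so compound 1 stands alongside compound 2 rather than apart from it; neither can be called the stronger on this evidence.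

Compound 3, `Cc1ccc(Nc2nc(Cl)nc3c2ncn3Cc2ccc(C(=O)Nc3ccccc3N)cc2)cc1`, has not yet been measured in this assay. It differs from compound 1 in one place: methyl in place of pyridin-2-yl on an aromatic carbon. Within the data shown here, whether compound 3 resembles or departs from compound 1 remains unknown, and no step between two measured compounds of this kind is available to guide the expectation. The two measured numbers give no sign of a wide spread, so the expected step from compound 1 to compound 3 is a number 4.8 percentage points lower from compound 1 to compound 3 (within the scatter), a change not clearly beyond the scatter. On that basis compound 3 is expected to give about 26% in this assay, with a likely range from 10% to 45%.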

Compound 3, a percentage reported as inhibition, at one concentration (the size of the read-out at that concentration, not a potency): 82.5%
Compound 3: the middle estimate sits 56.5 percentage points below what was measured; measured number above the stated range.
By their numbers in this assay, from the lowest: compounds 1 and 2 (each within the scatter of the next); then compound 3.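

In this assay, among these compounds, exchanging pyridin-2-yl for methyl on the six-membered aromatic ring of carbon only, para to a large group, gives a number 51.7 percentage points higher from compound 1 to compound 3 (beyond the scatter) and is the first comparison here of two compounds that differ in one place. It shows that the read-out responds strongly to what stands at this position, which the earlier numbers alone could not reveal. The change removes a whole ring and its nitrogen at once, leaving a single carbon, and no measurement available here explains the rise.

As far as these compounds go, the two compounds mark only two ends of a wide range of possible groups, so it remains open whether the size of the group or the ring nitrogen matters more: phenyl at this position would keep the ring without its nitrogen, while ethyl or methoxy would show how much room lies beyond methyl. Since the read-out gives the size of the effect at one concentration rather than a potency, a full concentration series on compound 3 would also be needed to say how potent it is.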